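The source may report more compounds than this note shows. Statements on the series, on what has been measured and on what is new or still open speak of the compounds shown alone.

Compound 3 `CC(C)C[C@H](N)c1cc(C(F)(F)F)ccc1N1CCN(C(=O)CCC(=O)N(C)C)CC1` carries a 2-(dimethylcarbamoyl)ethyl group on the carbonyl carbon of the shared core. In an assay on HEK293 cells for displacement of a labelled ligand from Melanocortin receptor 4 (Homo sapiens) (on this read-out higher numbers stand for weaker inhibition and lower numbers for stronger inhibition), compound 3 gives only a limit, > 10000 nM, so its true number is not known (the limit of > 10000 nM in this assay, at which 1 of the 3 values shown sits). Among the numbers shown it therefore stands at the weak end of the set. Compound 1 `CC(C)C[C@H](N)c1cc(C(F)(F)F)ccc1N1CCN(C(=O)C(C)Cc2ccc(Cl)cc2O)CC1`, which carries 1-(4-chloro-2-hydroxybenzyl)ethyl in that place, gives 36 nM in this assay, and compound 2 `CC(C)C[C@H](N)c1cc(C(F)(F)F)ccc1N1CCN(C(=O)COc2ccc3ccccc3c2)CC1`, with ((naphthalen-2-yl)oxy)methyl there, gives 2000 nM. Both the step of an at least 270-fold higher number from compound 1 to compound 3 (2.44 log units; beyond the scatter) and the step of an at least 5.0-fold higher number from compound 2 to compound 3 (0.69 log units; beyond the scatter) run toward weaker binding, the first of them large.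

Compound 4 `CC(C)C[C@H](N)c1cc(C(F)(F)F)ccc1N1CCN(C(=O)C(C)Cc2ccc(Cl)cc2)CC1` has not yet been measured. It differs from compound 3 as follows: 1-(4-chlorobenzyl)ethyl in place of 2-(dimethylcarbamoyl)ethyl on a carbonyl carbon. The entering group is the same as that of compound 1 except that the hydroxy group is missing, so the step that bears most on it is the reverse of an at least 270-fold higher number from compound 1 to compound 3 (2.44 log units; beyond the scatter), which was large. A large fall in the number is therefore expected in this assay, namely an at least 120-fold lower number from compound 3 to compound 4 (2.09 log units; beyond the scatter). The estimate for compound 4 is 80 nM, with a range from 20 nM to 400 nM.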

Compound 4, inhibition constant: 47 nM
Beside the measured number, compound 4's estimate is 1.7-fold (0.23 log units) above it; low and high end bracket the measured number.
By their numbers in this assay, from the lowest: compounds 1 and 4 (each within the scatter of the next); then compound 2. At a limit, above all of these: compound 3.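

Removing the hydroxy group from compound 1 leaves the binding read-out unresolved in this assay: with hydrogen in place of hydroxy on an aromatic carbon, the result is a 1.3-fold higher number from compound 1 to compound 4 (0.12 log units; within the scatter), so this hydroxy group is not needed to reach the low numbers seen here. The 1-(4-chlorobenzyl)ethyl group on the carbonyl carbon therefore keeps the advantage without it, as shown by a 43-fold lower number from compound 2 to compound 4 (1.63 log units; beyond the scatter), where it replaces ((naphthalen-2-yl)oxy)methyl, and by an at least 210-fold lower number from compound 3 to compound 4 (2.32 log units; beyond the scatter), where it replaces 2-(dimethylcarbamoyl)ethyl. Compound 3 gives only a limit, so the true size of that last step is not known: the limit of > 10000 nM in this assay, at which 1 of the 4 values shown sits.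

Compound 1 and compound 4 both keep the chlorine and the branching methyl of the chain, so the compounds shown cannot say what either of these contributes; a 1-benzylethyl group without chlorine, or a plain 2-(4-chlorophenyl)ethyl chain, would address that. They also leave open whether a different group in place of the hydroxy, such as an amine or a carboxylic acid, would leave the number unchanged as hydrogen does.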